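A few compounds are considered here, and "the series" means these few. Any claim that something is new, unique, unknown or untested is made for them only; others in the source may bear on it.

Three compounds built on one shared core differ only in the aryl group carried on the amide-type nitrogen. Compound 1 `CC(C)COc1ccc(NC(=O)CCCCCCCSc2nnc(Cc3nn(C)c(=O)c4ccccc34)n2C)cc1` gives 4800 nM in an assay on isolated protein (Mus musculus) for inhibition of IL15-IL15 receptor (Homo sapiens), read by resazurin assay, with stated times of 30 min and 2.5 days; a lower number here means a stronger inhibitor, a higher number a weaker inhibitor. Compound 2 `Cn1c(Cc2nn(C)c(=O)c3ccccc23)nnc1SCCCCCCCC(=O)Nc1ccc(O)cc1` reaches only a limit of this assay, > 30000 nM. Compound 3 `Cn1c(Cc2nn(C)c(=O)c3ccccc23)nnc1SCCCCCCCC(=O)Nc1ccc(Br)cc1Br` gives 1500 nM, the lowest of the two full numbers; the step of a 3.2-fold lower number from compound 1 to compound 3 (0.51 log units; beyond the scatter) was modest and the step of an at least 20-fold lower number from compound 2 to compound 3 (1.30 log units; beyond the scatter) was large. Compound 4 `Cn1c(Cc2nn(C)c(=O)c3ccccc23)nnc1SCCCCCCCC(=O)Nc1ccc(Cl)cc1` is not yet measured; the change is 4-chlorophenyl in place of 2,4-dibromophenyl on an amide-type nitrogen. Both measured steps swapped 4-(isobutoxy)phenyl or 4-hydroxyphenyl for 2,4-dibromophenyl and lowered the number, and compound 4 keeps one chlorine but loses both bromines, so a small rise, a 2.0-fold higher number from compound 3 to compound 4 (0.30 log units; within the scatter), is expected. Compound 4 is therefore estimated at 3000 nM, between 1200 nM and 8000 nM.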

Compound 4, half-maximal inhibitory concentration: 800 nM
For compound 4 the middle estimate is 3.8-fold (0.57 log units) above the measured one; the whole stated range lies above it.
By their numbers in this assay, from the lowest: compounds 4 and 3 (each within the scatter of the next); then compound 1. At a limit, above all of these: compound 2.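

Two bromines are not needed on the aryl group at this amide-type nitrogen: replacing 2,4-dibromophenyl with 4-chlorophenyl gives a 1.9-fold lower number from compound 3 to compound 4 (0.27 log units; within the scatter), so these two groups cannot be told apart here. Chloro in place of isobutoxy on the aromatic carbon gives a 6.0-fold lower number from compound 1 to compound 4 (0.78 log units; beyond the scatter). Chloro in place of hydroxy gives an at least 37-fold lower number from compound 2 to compound 4 (1.57 log units; beyond the scatter), but this step rests on a limit of the assay, not a number: the limit of > 30000 nM in this assay, at which 1 of the 4 values shown sits.

From the compounds shown here alone, whether plain phenyl, 4-fluorophenyl or 4-methylphenyl would match the chlorine remains open. So does the effect of an amine on the aromatic ring or a shorter chain before the amide.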